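The source may hold more compounds than are shown below. What is called first, only, known or untested is meant among the compounds shown, and "the series" means these compounds.

Measured so far:
- compound 1, `Cc1cccc(NC(=S)N/N=C/c2ccc3ccccc3n2)c1`: > 100000 nM
- compound 2, `NC(=S)N/N=C/c1cnc2ccccc2n1`: > 100000 nM

The study measured growth inhibition in a functional assay on SGC-7901 cells (Homo sapiens) for antiproliferative activity, read by sulforhodamine B assay, with a stated time of 72 h; a lower number here means a stronger inhibitor, a higher number a weaker inhibitor. For compound 1 the value > 100000 nM is a limit of the assay, not a number: its growth inhibition was too weak to be resolved. The same is true of compound 2, whose value > 100000 nM is also a limit. Compound 1 therefore stands at the limit of > 100000 nM in this assay, at which 2 of the 2 values shown sit, with nothing in the set of numbers that places one compound ahead of the other.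

Compound 3, `S=C(N/N=C/c1ccc2ccccc2n1)Nc1ccc(Br)cc1`, has not yet been measured. It differs from compound 1 in one place: 4-bromophenyl in place of 3-methylphenyl on an amide-type nitrogen. For the measured compounds named here, no pair of measured compounds shows what such a swap does in this assay, so the data offer no measured guide to its effect. Given that both measured compounds sit at the same limit, the step that the limit leaves unreadable from compound 1 to compound 3 from compound 1 to compound 3 is expected to be none beyond the usual scatter. For compound 3 the estimate in this assay is 150000 nM, within a range from 50000 nM to 500000 nM, most likely reported again as a limit rather than as a number.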

Compound 3, half-maximal inhibitory concentration: 69400 nM
For compound 3 the middle estimate is 2.2-fold (0.33 log units) above the measured one; low and high end bracket the measured number.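

In this assay, 4-bromophenyl in place of 3-methylphenyl on an amide-type nitrogen gives an at least 1.4-fold lower number from compound 1 to compound 3 (0.15 log units; that floor lies within the scatter). For the compounds shown here, this is the first view of what a change at this position can do, but it is only a floor, since one end of the step is a limit and the true size of the step cannot be read; the floor alone does not separate the two compounds beyond ordinary repeat variation. What sets compound 3 apart is that it alone carries a resolved number, while the other two compounds stay at one shared mark: the limit of > 100000 nM in this assay, at which 2 of the 3 values shown sit.

The compounds shown leave open whether the bromine itself or the place of the group on the phenyl ring matters, since the two groups differ in both respects, and a 3-bromophenyl or a 4-methylphenyl on the same nitrogen would tell these apart. They also leave open how this nitrogen would respond to a phenyl ring carrying an amine or a carboxylic acid, or to a plain ethyl chain in place of the ring.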